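Aryl swap on the pyrazole nitrogen: compound 3 to compound 4

The source may hold more compounds than are shown below. What is called first, only, known or untested is meant among the compounds shown, and "the series" means these compounds.

Three members of the series have numbers in an assay on CHO-K1 cells for antagonist activity at transient receptor potential cation channel subfamily V member 1 (Homo sapiens), read by FLIPR and calcium flux, with a stated time of 6 min; a higher number here means a weaker inhibitor, a lower number a stronger inhibitor. Compound 1 `CC(C)c1ccc(-n2nc(C(F)(F)F)cc2CNC(=O)Nc2cccc3[nH]ncc23)cc1` gives 4.1 nM. Compound 2 `Cc1ccc(-n2nc(C(F)(F)F)cc2CNC(=O)Nc2cccc3[nH]ncc23)cc1C` gives 2.8 nM. Compound 3 `Cn1ncc2c(NC(=O)NCc3cc(C(F)(F)F)nn3-c3cccc(F)c3)cccc21` gives 7 nM, the highest number of the three; against compound 1 its value sits within the usual scatter, against compound 2 the gap is beyond it. Within the data shown here, the only step between two measured compounds that differ in one place is a 1.5-fold lower number from compound 1 to compound 2 (0.17 log units; within the scatter), a change of the aryl group on the aromatic nitrogen that stays within the scatter.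

Compound 4 `Cn1ncc2c(NC(=O)NCc3cc(C(F)(F)F)nn3-c3ccc(C(F)(F)F)cc3)cccc21` is not yet measured. It differs from compound 3 in one place: 4-(trifluoromethyl)phenyl in place of 3-fluorophenyl on an aromatic nitrogen. Among the measured compounds shown here, this is the same kind of change as the one between compound 1 and compound 2, an exchange of one substituted phenyl for another on the aromatic nitrogen, and that step was a 1.5-fold lower number from compound 1 to compound 2 (0.17 log units; within the scatter). Nothing else in the data speaks to a 4-(trifluoromethyl)phenyl at this position. On that basis the step is expected to be small, no change at the digits printed from compound 3 to compound 4 (within the scatter), with no direction beyond the scatter. Compound 4 is therefore estimated at 7 nM, with a range of 3 nM to 16 nM in this assay.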

Compound 4, inhibition constant: 3.9 nM
Compound 4: middle estimate off by 1.8-fold (0.25 log units), on the high side, and the stated range covers the measured number.
By their numbers in this assay, from the lowest: compounds 2, 4, 1 and 3 (each within the scatter of the next, the first and the last beyond it).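

In this assay, the exchange of 3-fluorophenyl (7 heavy atoms) for 4-(trifluoromethyl)phenyl (10 heavy atoms) on the aromatic nitrogen gives a step that stays within the scatter (a 1.8-fold lower number from compound 3 to compound 4 (0.25 log units; within the scatter)). Among these compounds, this extends what the earlier compounds showed in two ways: the step on this aromatic nitrogen is now read on the core of compound 3 as well as on the core of compound 1, and it involves a fluorine-bearing phenyl group rather than only alkyl-substituted ones. Across the two steps available at this position, neither exchange of one substituted phenyl for another moves the number beyond the scatter, and no compound shown goes against this, but no evidence at hand explains the result.

All the groups shown at this position are phenyl rings bearing only alkyl or fluorine-containing substituents, so it remains open whether a phenyl carrying an amine or a carboxylic acid would fit the same picture. No pair shown places the same aryl group on both cores, so the contribution of the core itself remains open.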